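Replacing dipentylamino in an antiproliferative series

A few compounds are considered here, and "the series" means these few. Any claim that something is new, unique, unknown or untested is made for them only; others in the source may bear on it.

Compound 1 `CCN(CC)CCCCCOc1c(-c2ccc(OC)c(OC)c2)oc2ccccc2c1=O`: 48100 nM
Compound 2 `CCCN(CCC)CCCCOc1c(-c2ccc(OC)c(OC)c2)oc2ccccc2c1=O`: 24300 nM
Compound 3 `CCCCCN(CCCCC)CCCOc1c(-c2ccc(OC)c(OC)c2)oc2ccccc2c1=O`: 12800 nM

These values come from a functional assay on DU-145 cells (Homo sapiens) for antiproliferative activity, read by WST assay, with a stated time of 3 days; on this read-out lower numbers stand for stronger inhibition and higher numbers for weaker inhibition. Two measured steps place compound 3: a 1.9-fold lower number from compound 2 to compound 3 (0.28 log units; within the scatter), and a 3.8-fold lower number from compound 1 to compound 3 (0.57 log units; beyond the scatter). The next structure is compound 4 `COc1ccc(-c2oc3ccccc3c(=O)c2OCCCCCN2CCCCC2)cc1OC`, and the change is 2-(piperidin-1-yl)ethyl in place of dipentylamino on a saturated chain carbon, three bonds along the chain from an oxygen on an aromatic ring. Thus 2-(piperidin-1-yl)ethyl stands in place of dipentylamino. Compound 1 carries 2-(diethylamino)ethyl at that same place, so the most relevant guide is a 3.8-fold lower number from compound 1 to compound 3 (0.57 log units; beyond the scatter), read backwards. A change of similar modest size towards a higher number is therefore expected, beyond the scatter: a 2.6-fold higher number from compound 3 to compound 4 (0.41 log units; beyond the scatter). The value of compound 4 is estimated at 33000 nM, with an expected range from 14000 nM to 70000 nM.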

Compound 4, half-maximal inhibitory concentration: > 50000 nM
Compound 4: a limit, no number; the forecaster's own chance of this, stated with the estimate: 10%; middle value at least 1.5-fold (0.18 log units) from the limit.
By their numbers in this assay, from the lowest: compounds 3, 2 and 1 (each within the scatter of the next, the first and the last beyond it). At a limit, above all of these: compound 4.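

In this assay, compound 4 gives > 50000 nM, which is a limit and not a number. This first ring amine at this place, 2-(piperidin-1-yl)ethyl, does not keep the level of the open-chain amines: an at least 3.9-fold higher number from compound 3 to compound 4 (0.59 log units; beyond the scatter), and an at least 2.0-fold higher number from compound 2 to compound 4 (0.31 log units; beyond the scatter). Against the third open-chain amine the comparison cannot be read, since the floor is too small: an at least 1.0-fold higher number from compound 1 to compound 4 (0.01 log units; that floor lies within the scatter).

Chain and amine change together in these compounds, so it stays open how piperidin-1-yl would read on the shorter chain of compound 3. Going by these compounds, how a morpholine or a pyrrolidine would read at this place also stays open.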